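Trading the benzyl of compound 2 for cyclopentyl

The compounds below may be only part of what the source reports. "The series", "measured", "known", "first", "only" and "open" are said of these compounds alone.

Of the compounds shown here, three sharing one core have been measured in a functional assay on HCT-116 cells (Homo sapiens) for cytotoxicity, read by MTT assay, with a stated time of 48 h (on this read-out lower numbers stand for stronger inhibition of growth and higher numbers for weaker inhibition of growth), so far. Compound 1 `C=CCn1c(C(F)(F)F)nc2cc(Cl)c(Cl)cc21` gives 89200 nM in this test, compound 3 `O=[N+]([O-])c1cccc(Cn2c(C(F)(F)F)nc3cc(Cl)c(Cl)cc32)c1` gives 22800 nM here, and compound 2 `FC(F)(F)c1nc2cc(Cl)c(Cl)cc2n1Cc1ccccc1` gives 8600 nM as the lowest of the three numbers.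

Compound 4 `FC(F)(F)c1nc2cc(Cl)c(Cl)cc2n1C1CCCC1` has cyclopentyl in place of benzyl on an aromatic nitrogen and has not yet been measured. Within the data shown here, two measured steps bear on it, though neither tests cyclopentyl itself. The large step of a 10-fold lower number from compound 1 to compound 2 (1.02 log units; beyond the scatter) is the closer guide, since it also changes the group on that nitrogen and leaves the phenyl-free compound 1 with the higher number. The modest step of a 2.7-fold higher number from compound 2 to compound 3 (0.42 log units; beyond the scatter) shows that a change on the benzyl ring also moves the number. A modest to large rise is therefore expected, and the estimated change is a 2.9-fold higher number from compound 2 to compound 4 (0.46 log units; beyond the scatter) in this assay. For compound 4 the expected value is 25000 nM, with an estimated range from 9000 nM to 70000 nM.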

Compound 4, concentration for 50% growth inhibition: 22000 nM
Estimate against measurement, compound 4: 1.1-fold (0.06 log units) above; measured number inside the range.
By their numbers in this assay, from the lowest: compound 2; then compounds 4 and 3 (each within the scatter of the next); then compound 1.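

Compound 4 puts a carbon ring without aromatic character on the aromatic nitrogen, and in this assay this change gives a 2.6-fold higher number from compound 2 to compound 4 (0.41 log units; beyond the scatter) and so does not match benzyl. The same change also gives a 4.1-fold lower number from compound 1 to compound 4 (0.61 log units; beyond the scatter) in this assay, which shows that the gain over allyl at this position does not require the phenyl ring of benzyl, although cyclopentyl recovers only part of the step seen with benzyl. Nothing available explains why these groups differ.

The compounds shown leave open whether cyclopropyl, cyclohexyl or an open butyl chain on this nitrogen would fall near cyclopentyl. They also leave open how a chain ending in an amine or a carboxylic acid would behave at this position.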